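A Ring Closure on the Amine Tail of Compound 3

This account rests on a few compounds, and the source may have more. Where it says the series, first, only, none or still open, it means among the compounds named here.

Compound 3 `CN(C)CCNC(=O)CCC(=O)OCCCCCCSc1ccc([N+](=O)[O-])c2nonc12` gives the lowest number of the measured compounds in an assay on isolated protein for inhibition of glutathione S-transferase Mu 2 (Homo sapiens), with a stated time of 10 min (a higher number here means a weaker inhibitor, a lower number a stronger inhibitor), at 160 nM. Its nearest neighbour is compound 1 `O=C(CCC(=O)OCCCCCCSc1ccc([N+](=O)[O-])c2nonc12)Nc1ccccc1F`, which in this assay gives 350 nM, and the furthest is compound 2 `COc1ccc(NC(=O)CCC(=O)OCCCCCCSc2ccc([N+](=O)[O-])c3nonc23)cc1OC`, which gives 360 nM. Both distances are modest: a 2.2-fold lower number from compound 1 to compound 3 (0.34 log units; beyond the scatter), and a 2.3-fold lower number from compound 2 to compound 3 (0.35 log units; beyond the scatter). Compound 1 and compound 2 themselves sit close together, with a 1.0-fold higher number from compound 1 to compound 2 (0.01 log units; within the scatter).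

Compound 4 `O=C(CCC(=O)OCCCCCCSc1ccc([N+](=O)[O-])c2nonc12)NCCN1CCCC1` differs from compound 3 in one place: pyrrolidin-1-yl in place of dimethylamino on a saturated chain carbon, two bonds along the chain from an amide-type nitrogen. The amine stays where it was; only its two methyl groups are tied together into a ring. For the measured compounds named here, no measured step touches this part of the molecule. All of them exchange the whole group on the amide nitrogen, an aryl group against the aminoalkyl chain, and the amine tail itself has not been varied. The modest gains from compound 1 and compound 2 to compound 3 therefore show only that the aminoalkyl amide is the favourable choice, and say nothing about how the amine should be substituted. The step from compound 3 to compound 4 is expected to stay within the scatter, with no clear direction, a 1.1-fold lower number from compound 3 to compound 4 (0.03 log units; within the scatter). Compound 4 is estimated at 150 nM, between 70 nM and 330 nM.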

Compound 4, half-maximal inhibitory concentration: 200 nM
The estimate for compound 4 lay 1.3-fold (0.12 log units) below the measured number, and the stated range covers the measured number.
By their numbers in this assay, from the lowest: compounds 3, 4, 1 and 2 (each within the scatter of the next, the first and the last beyond it).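

In this assay, for the compounds shown here, the first change to the amine tail itself, tying the two methyl groups of dimethylamino into pyrrolidin-1-yl, does not separate the two groups (a 1.3-fold higher number from compound 3 to compound 4 (0.10 log units; within the scatter)). The position, on a saturated chain carbon two bonds along the chain from an amide-type nitrogen, therefore accepts this ring in place of the open dimethylamino group with no readable change in the number. The aryl comparison reads less clearly, since compound 4 stays within the scatter of both aryl amides (a 1.8-fold lower number from compound 2 to compound 4 (0.26 log units; within the scatter); a 1.8-fold lower number from compound 1 to compound 4 (0.24 log units; within the scatter)), whereas the corresponding steps to compound 3 lie just beyond it (a 2.3-fold lower number from compound 2 to compound 3 (0.35 log units; beyond the scatter); a 2.2-fold lower number from compound 1 to compound 3 (0.34 log units; beyond the scatter)), and no supporting data bear on this small difference.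

The compounds shown leave open whether a larger ring on the same nitrogen, such as piperidin-1-yl or morpholin-4-yl, would read the same way, and whether a primary amine or a hydroxyl group could take the place of the tertiary amine. They also leave open how a longer chain between the amide nitrogen and the amine would read.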